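Working notes on the amine side chain, compound 3 to compound 4

The source may hold more compounds than are shown below. What is called first, only, known or untested is meant among the compounds shown, and "the series" means these compounds.

In a functional assay for agonist activity at G protein-coupled receptor 88 (Homo sapiens), read by HTRF and cAMP accumulation (a higher number here means that more compound is needed for the effect, a lower number that less compound is needed), compound 1 `CC(C)C[C@H](N)CN(C(=O)[C@@H]1C[C@H]1c1ccccc1)c1ccc(-c2ccccc2)cc1` gives 880 nM. Compound 2 `CC(C)C[C@H](N)CN(C(=O)C(C)Cc1ccccc1)c1ccc(-c2ccccc2)cc1` gives 1.2 nM in this assay. Compound 3 `CC[C@H](C)[C@@H](CN(C(=O)[C@@H]1C[C@H]1c1ccccc1)c1ccc(-c2ccccc2)cc1)NC(C)=O` gives 5.8 nM in this assay, the second highest of the three numbers: compound 2 sits lower, compound 1 far higher. The two steps seen so far were a 730-fold lower number from compound 1 to compound 2 (2.87 log units; beyond the scatter) and a 150-fold lower number from compound 1 to compound 3 (2.18 log units; beyond the scatter). Compound 4 `CO[C@H](C)[C@H](N)CN(C(=O)[C@@H]1C[C@H]1c1ccccc1)c1ccc(-c2ccccc2)cc1` differs from compound 3 in one place: 1-amino-2-methoxypropyl in place of 1-acetamido-2-methylbutyl on a saturated chain carbon bound to an amide-type nitrogen. Going by the values given here, only the step from compound 1 to compound 3 touches this position; compound 4 partly reverses it, returning to a free amine as in compound 1, though with a different chain. A large rise in the number is therefore expected, a 52-fold higher number from compound 3 to compound 4 (1.71 log units; beyond the scatter). Compound 4 is estimated at 300 nM, between 40 nM and 2500 nM.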

Compound 4, half-maximal effective concentration: 0.68 nM
Compound 4: the middle estimate sits 440-fold (2.64 log units) above what was measured; measured number below the stated range.
By their numbers in this assay, from the lowest: compounds 4 and 2 (each within the scatter of the next); then compound 3; then compound 1.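

The free amine carries no penalty in itself at this position: with 1-amino-2-methoxypropyl in place of 1-acetamido-2-methylbutyl, this assay gives an 8.5-fold lower number from compound 3 to compound 4 (0.93 log units; beyond the scatter), so the acetamide of compound 3 is not needed for a low number. Going by these compounds alone, with the amine kept, 1-methoxyethyl in place of isobutyl gives a 1300-fold lower number from compound 1 to compound 4 (3.11 log units; beyond the scatter), the largest step so far. Nothing on hand accounts for the size of either step.

Still open, as far as these compounds go, is whether an ethoxy or a hydroxyl group in place of the methoxy would hold the number this low. Also open, from the compounds shown here alone, is what an acetamide on the chain of compound 4 would do.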